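This account rests on a few compounds, and the source may have more. Where it says the series, first, only, none or still open, it means among the compounds named here.

Measured so far:
compound 1, `CCCCCc1ccc(-c2cc3cn([C@H]4C[C@H](O)[C@@H](CO)O4)c(=O)nc3o2)cn1`: 100000 nM in an ADME assay on HEL cells (Homo sapiens) for cytotoxicity, with a stated time of 3 days; on this read-out higher numbers stand for lower toxicity in this test and lower numbers for higher toxicity in this test
compound 3, `CCCCCCc1ccc(-c2cc3cn([C@H]4C[C@H](O)[C@@H](CO)O4)c(=O)nc3o2)cn1`: 100000 nM in this assay
compound 2, `CCCCCc1ccc(-c2cc3cn([C@H]4C[C@H](O)[C@@H](CO)O4)c(=O)nc3o2)nc1`: its read-out is a limit of this assay, > 100000 nM

Compound 1 and compound 3 share a core and differ only in the chain: from compound 3 to compound 1 the change is hydrogen in place of methyl on a saturated chain carbon, five bonds along the chain from an aromatic carbon, and the step is no change at the digits printed from compound 3 to compound 1 (within the scatter). For compound 2 the read-out is a limit of > 100000 nM in this assay, at which 1 of the 3 values shown sits, and not a number. How the core of compound 2 differs from that of compound 3 is not broken down here.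

Compound 4, `CCCCc1ccc(-c2cc3cn([C@H]4C[C@H](O)[C@@H](CO)O4)c(=O)nc3o2)nc1`, is not yet measured. It stands to compound 2 as hydrogen in place of methyl on a saturated chain carbon, four bonds along the chain from an aromatic carbon, the same kind of change as the one before, though here the place is four bonds rather than five bonds along the chain from an aromatic carbon. Because the step of no change at the digits printed from compound 3 to compound 1 (within the scatter) showed nothing beyond the scatter, the step from compound 2 to compound 4 is expected to be a number no higher from compound 2 to compound 4 (the limit leaves the size open) in this assay. Compound 4 is thus estimated at 100000 nM, between 50000 nM and 200000 nM, with a fair chance that only a limit is reported.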

Compound 4, minimum cytotoxic concentration: > 100000 nM
Compound 4: only a limit was reported; the forecaster's own chance of this, stated with the estimate: 65%; the middle value lies on the limit itself.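

Between compound 2 and compound 4 no step can be read, since both give only a limit in this assay: the limit of > 100000 nM in this assay, at which 2 of the 4 values shown sit.

The compounds shown leave open where the actual values of compound 2 and compound 4 lie, and whether shortening the chain changes anything there.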